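Replacing 3-methoxyphenyl with 1H-benzimidazol-6-yl in compound 2

A few compounds are considered here, and "the series" means these few. Any claim that something is new, unique, unknown or untested is made for them only; others in the source may bear on it.

Compound 1 `CNC(=O)c1cc(C(=O)NC2CC2)cn(CC2CCCCC2)c1=O`: 4
Compound 2 `CNC(=O)c1cc(C(=O)NC2CC2)cn(Cc2cccc(OC)c2)c1=O`: 3

In a physicochemical assay for lipophilicity, at pH 7.4 (a higher number here means a more lipophilic compound, a lower number a more polar compound), compound 2 stands lower of the two measured compounds, at 3, beyond the scatter from compound 1. Compound 3 `CNC(=O)c1cc(C(=O)NC2CC2)cn(Cc2ccc3nc[nH]c3c2)c1=O` keeps the shared core and changes only the group on a saturated chain carbon bound to an aromatic nitrogen: 1H-benzimidazol-6-yl in place of 3-methoxyphenyl on a saturated chain carbon bound to an aromatic nitrogen. Among the compounds with values here, one measured step bears on this, at that same place: a number 1.00 log units lower from compound 1 to compound 2 (beyond the scatter). Within the data shown here, that single step is modest, and no measured compound yet carries the entering group, so the guidance is thin. On the strength of a number 1.00 log units lower from compound 1 to compound 2 (beyond the scatter), and with a hydrogen-bond donor entering where the leaving group has none, a further downward move of similar size is expected. The estimate amounts to a number 0.80 log units lower from compound 2 to compound 3 (beyond the scatter), as an expected step. For compound 3 the estimated value is 2.2, with an expected range from 1.6 to 2.8.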

Compound 3, distribution coefficient: 1.2
For compound 3 the middle estimate is 1.00 log units above the measured one; measured number below the stated range.
By their numbers in this assay, from the lowest: compound 3; then compound 2; then compound 1.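

In this assay, the place on a saturated chain carbon bound to an aromatic nitrogen turns out to allow a much larger move than the earlier pair showed: 1H-benzimidazol-6-yl in place of 3-methoxyphenyl gives a number 1.80 log units lower from compound 2 to compound 3 (beyond the scatter), a large step where the earlier one was a number 1.00 log units lower from compound 1 to compound 2 (beyond the scatter). Measured against the cyclohexyl group of compound 1, the same place now spans a number 2.80 log units lower from compound 1 to compound 3 (beyond the scatter), so the choice of this one group covers a wide stretch of the scale while the shared core stays fixed. Nothing measured here explains the size of the step.

The compounds shown do not separate the hydrogen-bond donor of 1H-benzimidazol-6-yl from the rest of its two-ring system. An indole, or a benzimidazole carrying a methyl group on its ring nitrogen, at this place remains an open case.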